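Methoxycarbonyl in place of cyano on the five-membered ring

This account rests on a few compounds, and the source may have more. Where it says the series, first, only, none or still open, it means among the compounds named here.

compound 1 `N#Cc1ccccc1-c1cnc(C(=O)CCCCCCc2ccccc2)o1` — 130 nM
compound 2 `N#Cc1cnc(C(O)CCCCCCc2ccccc2)o1` — 4200 nM

In an assay (Rattus norvegicus) for inhibition of Fatty-acid amide hydrolase 1 (Homo sapiens) (a lower number here means a stronger inhibitor, a higher number a weaker inhibitor), compound 1 gives 130 nM and compound 2 gives 4200 nM. Compound 2 thus holds the highest number of the two measured, with the gap to compound 1 beyond the scatter. Compound 3 `COC(=O)c1cnc(C(O)CCCCCCc2ccccc2)o1` is compound 2 with methoxycarbonyl in place of cyano on an aromatic carbon. Among the measured compounds shown here, no measured pair isolates this change, so nothing is known of its size. The step from compound 2 is expected to be small, if anything toward a slightly higher number, about a 1.3-fold higher number from compound 2 to compound 3 (0.12 log units; within the scatter) in this assay, within the scatter. Compound 3 is accordingly estimated at 5500 nM, in the range 1500 nM to 20000 nM.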

Compound 3, inhibition constant: 2000 nM
Beside the measured number, compound 3's estimate is 2.8-fold (0.44 log units) above it, and the stated range covers the measured number.
By their numbers in this assay, from the lowest: compound 1; then compound 3; then compound 2.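

In this assay, the aromatic carbon next to the ring oxygen accepts methoxycarbonyl in place of cyano with a modest gain, a 2.1-fold lower number from compound 2 to compound 3 (0.32 log units; beyond the scatter). Among the compounds shown here, this is the first measured read on this change, and it shows that the position does not depend on the nitrile and can carry an ester with the chain unchanged. Nothing available explains the step.

On these data alone, it remains open whether a carboxylic acid or a primary amide at this position would move the number further. Also open, as far as these compounds go, is whether the same exchange holds with a carbonyl in the chain in place of the hydroxyl.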